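This account rests on a few compounds, and the source may have more. Where it says the series, first, only, none or still open, it means among the compounds named here.

Measured compounds:
compound 1, `Nc1nc(NCc2ccccc2)nc(-c2c(F)cccc2CO)n1`: 3.69
compound 2, `Nc1nc(NCc2ccccc2F)nc(-c2ccccc2CO)n1`: 4.27

Among the compounds with values here, in a functional assay on cells for positive allosteric modulation of G-protein coupled receptor 68 (Homo sapiens), read by a luciferase reporter and cAMP accumulation, with a stated time of 30 min, at pH 6.8 and pH 8.3, in the presence of a further agent that is not named here (a higher number here means a more potent compound, by a factor of ten per unit of this negative logarithm, a lower number a less potent compound), compound 2 gives 4.27, the higher of the two numbers so far. Within the data shown here, compound 1 is the only comparison, and in this assay compound 1 gives 3.69, which stands lower by a margin beyond the usual scatter. Among the measured compounds shown here, the two compounds differ in more than one place, so no single step between them has been worked out; the pair shows only that compound 2 is the more potent of the two.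

Compound 3, `Nc1nc(NCc2ccccc2F)nc(-c2c(F)cccc2CO)n1`, has not yet been measured in this assay. Relative to compound 2 the change is fluoro in place of hydrogen on an aromatic carbon; the ring that carries the hydroxymethyl group now also carries a fluorine, as in compound 1, while the fluorine of compound 2 is kept. For the measured compounds named here, no measured pair isolates this change, so its size in this assay is open; a small step in either direction, not beyond the scatter, is the expectation, written as a number 0.12 log units lower from compound 2 to compound 3 (within the scatter). Compound 3 is therefore estimated at 4.15, with a range from 3.55 to 4.75.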

Compound 3, negative logarithm of the antagonist equilibrium constant: 4.22
Estimate against measurement, compound 3: 0.07 log units below; low and high end bracket the measured number.
By their numbers in this assay, from the lowest: compound 1; then compounds 3 and 2 (each within the scatter of the next).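

In this assay, fluoro in place of hydrogen on an aromatic carbon, ortho to a large group and meta to a hydroxymethyl group, gives a number 0.05 log units lower from compound 2 to compound 3 (within the scatter), so this position accepts a fluoro with no difference that can be read beyond the scatter. On the other aromatic ring, with the fluoro on the hydroxymethyl-bearing ring present in both compounds, fluoro in place of hydrogen gives a number 0.53 log units higher from compound 1 to compound 3 (beyond the scatter), a modest step and the first one in the series that lies beyond the scatter. No measurement of any other property accompanies these numbers, and nothing here accounts for either step.

The compounds shown compare only hydrogen and fluoro at each of these two places, so it remains open how a chloro, a methoxy or an amine would read at either one. Also open is whether the hydroxymethyl group matters in this assay, since a carboxylic acid or a longer chain in its place does not appear among the compounds shown, and the compound with hydrogen at both places is likewise absent from them.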